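Lengthening an Ester Side Chain: Compound 2 to Compound 3

The source may hold more compounds than are shown below. What is called first, only, known or untested is meant among the compounds shown, and "the series" means these compounds.

Measured in a functional assay on MCF7 cells (Homo sapiens) for cytotoxicity, read by neutral red uptake, with a stated time of 3 days; on this read-out lower numbers stand for stronger inhibition and higher numbers for weaker inhibition:
Compound 1 `CN(C)c1c(F)c(N)c2c(=O)cc(-c3ccc(N)c(F)c3)oc2c1F` gives 39 nM.
Compound 2 `CN(C)CC(=O)OCc1c(F)c(N)c2c(=O)cc(-c3ccc(N)c(F)c3)oc2c1F` gives 26 nM.

Among the measured compounds shown here, compound 2 holds the lower of the two numbers, yet the only step, a 1.5-fold lower number from compound 1 to compound 2 (0.18 log units; within the scatter), lies within the scatter, so neither compound can be called stronger. Compound 3 `CN(C)CCCC(=O)OCc1c(F)c(N)c2c(=O)cc(-c3ccc(N)c(F)c3)oc2c1F` differs from compound 2 by 2-(dimethylamino)ethyl in place of dimethylamino on a saturated chain carbon bound to a carbonyl carbon. For the measured compounds named here, no measured step covers this kind of chain lengthening; the one step known stayed within the scatter. In this assay the step of a 1.2-fold higher number from compound 2 to compound 3 (0.06 log units; within the scatter) is therefore expected to stay within the scatter, with no clear direction. Compound 3 is estimated at 30 nM, ranging from 12 nM to 75 nM.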

Compound 3, half-maximal inhibitory concentration: 29 nM
Estimate against measurement, compound 3: 1.0-fold (0.01 log units) above; the range from low to high includes it.
By their numbers in this assay, from the lowest: compounds 2, 3 and 1 (each within the scatter of the next).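

In this assay putting 2-(dimethylamino)ethyl in place of dimethylamino on a saturated chain carbon bound to a carbonyl carbon gives a 1.1-fold higher number from compound 2 to compound 3 (0.05 log units; within the scatter) and so does not separate the two compounds. Likewise, (((3-(dimethylamino)propyl)carbonyl)oxy)methyl in place of dimethylamino on an aromatic carbon gives a 1.3-fold lower number from compound 1 to compound 3 (0.13 log units; within the scatter) and does not separate those two. No supporting measurement bears on these results.

On these data alone, whether a still longer chain would also stay within the scatter remains open. The same question holds for a carboxylic acid in place of dimethylamino.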